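This account rests on a few compounds, and the source may have more. Where it says the series, first, only, none or still open, it means among the compounds named here.

Measured so far in a functional assay on A549 cells (Homo sapiens) for antiproliferative activity, read by MTT assay, with a stated time of 48 h; on this read-out higher numbers stand for weaker inhibition and lower numbers for stronger inhibition:
- compound 1 `C/C(=C\CC/C(C)=C/CC[C@@H]1[C@@]2(C)CCC(=O)C(C)(C)[C@H]2CC[C@@]1(C)O)CC/C=C(\C)C(=O)OCc1cn(-c2ccccc2[N+](=O)[O-])nn1`: > 150000 nM (a limit)
- compound 2 `C/C(=C\CC/C(C)=C/CC[C@@H]1[C@@]2(C)CCC(=O)C(C)(C)[C@H]2CC[C@@]1(C)O)CC/C=C(\C)C(=O)OCc1cn(-c2ccc(F)c(Cl)c2)nn1`: > 150000 nM (a limit)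
- compound 3 `C#CCOC(=O)/C(C)=C/CC/C(C)=C/CC/C(C)=C/CC[C@@H]1[C@@]2(C)CCC(=O)C(C)(C)[C@H]2CC[C@@]1(C)O`: 45100 nM

In this series, compound 2 gives only a limit, > 150000 nM, and not a number. Compound 1 is also reported only as a limit, > 150000 nM. Within the data shown here, compound 3 is the only one with a number, 45100 nM.

The next compound is compound 4 `COc1ccc(-n2cc(COC(=O)/C(C)=C/CC/C(C)=C/CC/C(C)=C/CC[C@@H]3[C@@]4(C)CCC(=O)C(C)(C)[C@H]4CC[C@@]3(C)O)nn2)cc1`, which keeps the shared core and ester link of compound 2 and changes only the group on the aromatic nitrogen: 4-methoxyphenyl in place of 3-chloro-4-fluorophenyl on an aromatic nitrogen. Among the measured compounds shown here, the one measured change at this place is a step that the two limits leave unreadable from compound 1 to compound 2, so it offers no size to carry over. Compound 4 keeps a substituted benzene ring on that nitrogen, as compound 1 and compound 2 do, and is expected to lie close to them because of the limit of > 150000 nM in this assay, at which 2 of the 3 values shown sit. No step beyond the scatter can be expected in this assay, and no direction can be assigned. A report of a limit is the likelier outcome.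

The estimate for compound 4 is 150000 nM, with an expected range of 60000 nM to 300000 nM. The expected change is thus a number no higher from compound 2 to compound 4 (the limit leaves the size open).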

Compound 4, half-maximal inhibitory concentration: > 150000 nM
Compound 4: only a limit was reported (the forecaster's own chance of this, stated with the estimate: 70%); the middle value lies on the limit itself.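

No new step can be read in this assay: compound 1, compound 2 and compound 4 are all reported only as limits, so the steps among them cannot be read. The compounds shown leave open how far these three lie from one another and whether any aryl group on that aromatic nitrogen gives a measurable number.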